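The source may report more compounds than this note shows. Statements on the series, on what has been measured and on what is new or still open speak of the compounds shown alone.

Measured compounds in the series:
compound 1 `CCOC(=O)C1CCN(C(=O)CN2CN(c3ccccc3)C3(CCN(C(=O)c4ccc(C5CCCCC5)cc4)CC3)C2=O)CC1` — 900 nM
compound 2 `CC(C)(C)OC(=O)NC1CCN(C(=O)CN2CN(c3ccccc3)C3(CCN(C(=O)c4ccc(C5CCCCC5)cc4)CC3)C2=O)CC1` — 4800 nM
compound 3 `CC(C)(C)c1ccc(C(=O)N2CCC3(CC2)C(=O)N(CC(=O)NCNS(C)(=O)=O)CN3c2ccccc2)cc1` — 3200 nM

In an assay on HEK293 cells for displacement of a labelled ligand from NPC1-like intracellular cholesterol transporter 1 (Homo sapiens) (a higher number here means a weaker inhibitor, a lower number a stronger inhibitor), compound 1 gives the lowest number of the three; compound 2 and compound 3 both sit higher, each beyond the scatter. Among the compounds with values here, the one single-point step in hand is a 5.3-fold higher number from compound 1 to compound 2 (0.73 log units; beyond the scatter), where a group carrying a hydrogen-bond donor replaced an ester on the saturated ring. Within the data shown here, compound 3, which carries a methanesulfonamide-bearing open chain on the amide nitrogen, shows a higher number than compound 1, though it also differs elsewhere, so no step is counted for that pair.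

Compound 4 `CS(=O)(=O)NCCCNC(=O)CN1CN(c2ccccc2)C2(CCN(C(=O)c3ccc(C4CCCCC4)cc3)CC2)C1=O` has not been measured. It differs from compound 1 as follows: (3-(methanesulfonamido)propyl)amino in place of 4-(ethoxycarbonyl)piperidin-1-yl on a carbonyl carbon. The ring is lost and two hydrogen-bond donors arrive. Among the measured compounds shown here, both comparisons available point the same way: the donor-introducing step from compound 1 to compound 2 weakened binding, and compound 3, the only measured compound with a methanesulfonamide chain, sits above compound 1. A modest rise in this assay is therefore expected, a 3.3-fold higher number from compound 1 to compound 4 (0.52 log units; beyond the scatter). Compound 4 is estimated at 3000 nM, with a range of 1000 nM to 9000 nM.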

Compound 4, half-maximal inhibitory concentration: 3800 nM
The estimate for compound 4 lay 1.3-fold (0.10 log units) below the measured number; the range from low to high includes it.
By their numbers in this assay, from the lowest: compound 1; then compounds 3, 4 and 2 (each within the scatter of the next).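

In this assay, replacing the whole 4-(ethoxycarbonyl)piperidin-1-yl on the carbonyl carbon with the open (3-(methanesulfonamido)propyl)amino chain gives a 4.2-fold higher number from compound 1 to compound 4 (0.63 log units; beyond the scatter), so the change in number at this end of the molecule is no longer confined to a swap on the saturated ring, the only case shown by a 5.3-fold higher number from compound 1 to compound 2 (0.73 log units; beyond the scatter). Compound 2 and compound 4 lie within the scatter of each other, and compound 1 has the lowest number of the pair-wise comparisons with both. Nothing measured here accounts for the higher number of compound 4.

This change removes the ring and adds hydrogen-bond donors together, so the two cannot be separated. A plain propylamino chain without the methanesulfonamide, or a carboxylic acid in place of the ester on the piperidine, would bear on this; neither is among the compounds shown.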